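Moving from a piperidine to a pyridine amide

The source may report more compounds than this note shows. Statements on the series, on what has been measured and on what is new or still open speak of the compounds shown alone.

Compound 1 `O=C(Nc1nccs1)c1cccc(Nc2ncc(F)c(Nc3ccc(F)cc3)n2)c1`: > 10000 nM (a limit of the assay)
Compound 2 `COc1ccc(NC(=O)c2cccc(Nc3ncc(F)c(Nc4ccc(F)cc4)n3)c2)cc1`: 11000 nM
Compound 3 `CN1CCC(C(=O)Nc2cccc(Nc3ncc(F)c(Nc4ccc(F)cc4)n3)c2)CC1`: 1330 nM

Compound 3 has the lowest number in a functional assay on A549 cells (Homo sapiens) for antiproliferative activity, read by sulforhodamine B assay, with a stated time of 3 days (a higher number here means a weaker inhibitor of growth, a lower number a stronger inhibitor of growth), and compound 2 is its nearest measured neighbour. The measured comparison there is an 8.3-fold lower number from compound 2 to compound 3 (0.92 log units; beyond the scatter). The limit for compound 1 still allows a reading of an at least 7.5-fold lower number from compound 1 to compound 3 (0.87 log units; beyond the scatter). The remaining comparison is a step that the limit leaves unreadable from compound 1 to compound 2.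

Compound 4 `O=C(Nc1cccc(Nc2ncc(F)c(Nc3ccc(F)cc3)n2)c1)c1ccncc1` is the next case, with pyridin-4-yl in place of 1-methylpiperidin-4-yl on a carbonyl carbon. The measured steps bear on this change only in part. Each swaps the whole ((1-methylpiperidin-4-yl)carbonyl)amino group for a carbamoyl group, whereas compound 4 keeps the carbonylamino form of compound 3. Even so, compound 4 shares with compound 1 and compound 2 an aromatic ring on the amide, and among these three compounds only compound 3 has a non-aromatic ring there. Within the data shown here, no measured compound goes against this pattern, but it rests on very few compounds.

A higher number is therefore expected for compound 4 than for compound 3. The measured guide to its size is an 8.3-fold lower number from compound 2 to compound 3 (0.92 log units; beyond the scatter). The amide form of compound 3 is retained in compound 4, and a smaller change than that one is expected. The expected change is a 3.0-fold higher number from compound 3 to compound 4 (0.48 log units; beyond the scatter). For compound 4 the estimated value is 4000 nM, with an expected range of 1200 nM to 13000 nM.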

Compound 4, concentration for 50% growth inhibition: 1650 nM
Beside the measured number, compound 4's estimate is 2.4-fold (0.38 log units) above it, within the range that was stated.
By their numbers in this assay, from the lowest: compounds 3 and 4 (each within the scatter of the next); then compound 2.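

In this assay, exchanging the non-aromatic 1-methylpiperidin-4-yl on the carbonyl carbon for the aromatic pyridin-4-yl gives a 1.2-fold higher number from compound 3 to compound 4 (0.09 log units; within the scatter), so an aromatic ring on the amide does not in itself go with the high numbers of compound 1 and compound 2. The earlier contrast therefore no longer reads as one between non-aromatic and aromatic rings: with an aromatic ring on both sides, the change of the whole group still gives a 6.7-fold lower number from compound 2 to compound 4 (0.82 log units; beyond the scatter), and among these four compounds the two carbonylamino compounds, compound 3 and compound 4, have the lower numbers, with no compound going against this. Compound 1 is held at a limit of the assay, and an at least 6.0-fold lower number from compound 1 to compound 4 (0.78 log units; beyond the scatter) is read from that limit: the limit of > 10000 nM in this assay, at which 1 of the 4 values shown sits.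

A plain phenyl or a cyclohexyl on the same carbonyl carbon would show whether the ring nitrogen of pyridin-4-yl and 1-methylpiperidin-4-yl counts at this place. A 4-methoxyphenyl or 1,3-thiazol-2-yl on that carbonyl carbon would separate the effect of the carbonylamino form from that of the ring it carries.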